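From Formyl to Hydroxymethyl: What Compound 3 Might Show

The source may hold more compounds than are shown below. What is called first, only, known or untested is meant among the compounds shown, and "the series" means these compounds.

Of the compounds shown here, two on one shared core have been measured in an assay on isolated protein for inhibition of Amine oxidase [flavin-containing] B (Homo sapiens), read by fluorescence and spectrophotometry, with a stated time of 20 min; on this read-out lower numbers stand for stronger inhibition and higher numbers for weaker inhibition. Compound 1 `COn1c(-c2ccc(C)cc2)c(C=O)c2cc(C#N)c(C#N)cc21` gives 74800 nM in this assay. Compound 2 `COc1ccc(-c2c(C=O)c3cc(C#N)c(C#N)cc3n2OC)cc1` reaches only a limit of the assay, > 100000 nM in this assay. Compound 2 thus stands at the limit of > 100000 nM in this assay, at which 1 of the 2 values shown sits, the weak edge of what the assay reports. For the measured compounds named here, the one measured step, an at least 1.3-fold higher number from compound 1 to compound 2 (0.12 log units; that floor lies within the scatter), concerns a different site and not the group that now changes. Compound 3 `COc1ccc(-c2c(CO)c3cc(C#N)c(C#N)cc3n2OC)cc1` differs from compound 2 by hydroxymethyl in place of formyl on an aromatic carbon. Going by the values given here, no measured step bears on this exchange, so its size and direction are not fixed by the data, and compound 2 is already at the limit. Compound 3 is therefore expected to remain at or near that limit, a step that the limit leaves unreadable from compound 2 to compound 3. The estimate for compound 3 in this assay is 200000 nM, with a range from 60000 nM to 600000 nM.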

Compound 3, half-maximal inhibitory concentration: > 100000 nM
Compound 3 ended at the assay's limit; the forecaster's own chance of this, stated with the estimate: 70%; the middle value lies beyond the limit too.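

Compound 2 and compound 3 both sit at a limit of the assay, and no step can be read between them for hydroxymethyl in place of formyl on an aromatic carbon. The compounds shown leave open whether this exchange alters inhibition at all, and in which direction.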